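Aryl variation on the ring nitrogen: toward compound 4

A few compounds are considered here, and "the series" means these few. Any claim that something is new, unique, unknown or untested is made for them only; others in the source may bear on it.

Measured compounds:
Compound 1 `CCc1ccccc1-n1nncc1CN1C(=O)C2(C(C#N)=C(N)Oc3c(N)cc4nc5ccccc5nc4c32)c2ccccc21`. In an ADME assay on HUVEC cells (Homo sapiens) for antiproliferative activity, read by MTT assay, with a stated time of 48 h (on this read-out lower numbers stand for stronger inhibition and higher numbers for weaker inhibition), compound 1 gives > 50000 nM, which is a limit of the assay and not a number.
Compound 2 `CCOc1ccccc1-n1nncc1CN1C(=O)C2(C(C#N)=C(N)Oc3c(N)cc4nc5ccccc5nc4c32)c2ccccc21`. In this assay compound 2 gives > 50000 nM, again a limit.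
Compound 3 `N#CC1=C(N)Oc2c(N)cc3nc4ccccc4nc3c2C12C(=O)N(Cc1cnnn1-c1ccc([N+](=O)[O-])cc1[N+](=O)[O-])c1ccccc12`. In this assay compound 3 gives > 50000 nM, also a limit.

Compound 3 therefore stands at the ceiling of what was measured, with no numerical value of its own; the whole set sits there (the limit of > 50000 nM in this assay, at which 3 of the 3 values shown sit). The steps among the measured compounds, a step that the two limits leave unreadable from compound 1 to compound 2, a step that the two limits leave unreadable from compound 1 to compound 3 and a step that the two limits leave unreadable from compound 2 to compound 3, are all unreadable in size, since both ends are limits. None of them gives a direction for a further change at the same position.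

Compound 4 `N#CC1=C(N)Oc2c(N)cc3nc4ccccc4nc3c2C12C(=O)N(Cc1cnnn1-c1c(Cl)cc(Cl)cc1Cl)c1ccccc12` differs from compound 3 in one place: 2,4,6-trichlorophenyl in place of 2,4-dinitrophenyl on an aromatic nitrogen. The earlier changes at this nitrogen, ethyl, ethoxy and dinitro variants of the phenyl ring, all left the read-out at the limit, so no step beyond the scatter is expected here either; the step of a number no higher from compound 3 to compound 4 (the limit leaves the size open) from compound 3 to compound 4 is expected to be unreadable in the same way. Compound 4 is estimated at 50000 nM, within 20000 nM to 100000 nM, most likely reported again only as a limit.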

Compound 4, half-maximal inhibitory concentration: 18300 nM
The estimate for compound 4 lay 2.7-fold (0.44 log units) above the measured number, outside the stated range (below it).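

In this assay, among these compounds, 2,4,6-trichlorophenyl on the aromatic nitrogen gives the only readable steps at this position: an at least 2.7-fold lower number from compound 3 to compound 4 (0.43 log units; beyond the scatter), an at least 2.7-fold lower number from compound 2 to compound 4 (0.43 log units; beyond the scatter) and an at least 2.7-fold lower number from compound 1 to compound 4 (0.43 log units; beyond the scatter). From the compounds shown here alone, the steps among compound 1, compound 2 and compound 3 cannot be read, and each of the three new steps starts from a limit, so its full size stays open. The aryl group on this nitrogen can therefore bring the read-out off the ceiling, and among the compounds shown only compound 4 does so: the limit of > 50000 nM in this assay, at which 3 of the 4 values shown sit.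

Open, going by these compounds, is whether a phenyl ring carrying a single chlorine, an amine or a carboxylic acid would keep, extend or lose this step. Also open, on these data alone, is how much further a change at this nitrogen can lower the number from that of compound 4, 18300 nM.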